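Dropping One Methoxy from the Strongest Inhibitor

A few compounds are considered here, and "the series" means these few. Any claim that something is new, unique, unknown or untested is made for them only; others in the source may bear on it.

Compound 1 `COc1ccc(C(=O)c2ccc3c(ccn3Cc3ccc(C(=O)NO)cc3)c2)cc1OC` gives 15.5 nM in an assay on isolated protein for inhibition of protein deacetylase HDAC6 (Homo sapiens) (a higher number here means a weaker inhibitor, a lower number a stronger inhibitor), the lowest number among the three measured compounds; compound 2 `COc1cc(C(=O)c2ccc3c(ccn3Cc3ccc(C(=O)NO)cc3)c2)cc(OC)c1OC` gives 1540 nM and compound 3 `COc1cc(C(=O)c2ccc3c(ccn3Cc3ccc(/C=C/C(=O)NO)cc3)c2)cc(OC)c1OC` gives 143 nM. Compound 4 `COc1cccc(C(=O)c2ccc3c(ccn3Cc3ccc(C(=O)NO)cc3)c2)c1` differs from compound 1 by hydrogen in place of methoxy on an aromatic carbon. Among the compounds with values here, the only step touching the same ring, a 99-fold higher number from compound 1 to compound 2 (2.00 log units; beyond the scatter), shows that adding a methoxy there weakened inhibition sharply; the step of an 11-fold lower number from compound 2 to compound 3 (1.03 log units; beyond the scatter) concerns a different part of the molecule. Within the data shown here, no measured step removes a methoxy, so the direction is uncertain, and a change in this assay near the scatter is expected. Compound 4 is therefore estimated at 25 nM, with a range from 8 nM to 80 nM, a step of a 1.6-fold higher number from compound 1 to compound 4 (0.21 log units; within the scatter).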

Compound 4, half-maximal inhibitory concentration: 16.4 nM
For compound 4 the middle estimate is 1.5-fold (0.18 log units) above the measured one; the range from low to high includes it.
By their numbers in this assay, from the lowest: compounds 1 and 4 (each within the scatter of the next); then compound 3; then compound 2.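

In this assay the step of a 1.1-fold higher number from compound 1 to compound 4 (0.02 log units; within the scatter) shows that hydrogen and methoxy are interchangeable at this place, ortho to a methoxy group. The earlier step of a 99-fold higher number from compound 1 to compound 2 (2.00 log units; beyond the scatter) showed only that one added methoxy on this ring can weaken inhibition sharply, so the ring's sensitivity is not the same for every methoxy. Nothing available explains this contrast.

Open, as far as these compounds go, is whether this place would also accept an amine or a longer chain, and whether the remaining methoxy of the 3-methoxyphenyl group matters.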